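Phenyl in Place of 1H-indol-3-yl, Measured Twice

The compounds below may be only part of what the source reports. "The series", "measured", "known", "first", "only" and "open" are said of these compounds alone.

Compound 1 `COc1ccc(Cn2c(CCc3c[nH]c4ccccc34)nnc2[C@H](NC(=O)C(C)(C)N)c2c[nH]c3ccccc23)c(OC)c1` and compound 2 `COc1ccc(Cn2c(CCc3ccccc3)nnc2[C@H](NC(=O)C(C)(C)N)c2c[nH]c3ccccc23)c(OC)c1` share one core, while compound 3 `COc1ccc(Cn2c(CCc3c[nH]c4ccccc34)nnc2[C@H](NC(=O)c2ccccn2)c2c[nH]c3ccccc23)cc1` and the not-yet-measured compound 4 `COc1ccc(Cn2c(CCc3ccccc3)nnc2[C@H](NC(=O)c2ccccn2)c2c[nH]c3ccccc23)cc1` share another. How the core of compound 1 differs from the core of compound 3 is not broken down here.

In a functional assay on CHO cells for antagonist activity at growth hormone secretagogue receptor type 1 (Homo sapiens) (on this read-out lower numbers stand for stronger inhibition and higher numbers for weaker inhibition), compound 1 gives 14 nM, and compound 2 gives 17 nM. The change between them is phenyl in place of 1H-indol-3-yl on a saturated chain carbon, two bonds along the chain from an aromatic carbon, and it produced a 1.2-fold higher number from compound 1 to compound 2 (0.08 log units; within the scatter), so the two numbers cannot be told apart with confidence. In this assay compound 3 gives 102 nM, the highest number among the three measured compounds and beyond the scatter from both others.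

The change from compound 3 to compound 4 is phenyl in place of 1H-indol-3-yl on a saturated chain carbon, two bonds along the chain from an aromatic carbon. The place is described in the same words as before, so this is the same change repeated on a second core. For compound 4 the step is expected to be a 1.1-fold higher number from compound 3 to compound 4 (0.05 log units; within the scatter), resting on the earlier step of a 1.2-fold higher number from compound 1 to compound 2 (0.08 log units; within the scatter), which stayed within the scatter. In this assay compound 4 is therefore estimated at 115 nM, with a likely range from 55 nM to 250 nM.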

Compound 4, antagonist equilibrium constant: 12 nM
The estimate for compound 4 lay 9.6-fold (0.98 log units) above the measured number; measured number outside the range, below it.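

In this assay, putting phenyl in place of 1H-indol-3-yl gave an 8.5-fold lower number from compound 3 to compound 4 (0.93 log units; beyond the scatter), which means stronger inhibition on this core, whereas the same swap on the core of compound 1 made no readable difference. The two results clearly disagree, so the effect of this change did not carry from one core to the other: the same change on two cores in this assay, a 1.2-fold higher number (0.08 log units; within the scatter) from compound 1 to compound 2 and an 8.5-fold lower number (0.93 log units; beyond the scatter) from compound 3 to compound 4, 10-fold (1.01 log units) apart, beyond the scatter of two such steps. This shows that, across these two pairs, a result obtained on one core was a poor guide to the other, but it does not show which part of the cores is responsible, or why the swap helps on only one of them.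

Two pairs also leave open how the change would behave on any further core. As far as these compounds go, it also remains unknown whether a longer chain such as 3-phenylpropyl, or an amine or a carboxylic acid on the phenyl ring, would keep the strength of compound 4 in this series.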